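Methyl for 2,4-Difluorophenyl on a Sulfonyl Sulfur

The source may report more compounds than this note shows. Statements on the series, on what has been measured and on what is new or still open speak of the compounds shown alone.

Of the compounds shown here, three have been measured in a functional assay on HCT-116 cells (Homo sapiens) for antiproliferative activity, read by sulforhodamine B assay, with a stated time of 72 h; on this read-out lower numbers stand for stronger inhibition and higher numbers for weaker inhibition. Compound 1 `COc1ncc(-c2ccc3ncnc(Nc4ccc(OCCO)nc4)c3c2)cc1NS(C)(=O)=O` gives 5360 nM, compound 3 `COc1ncc(-c2ccc3ncnc(Nc4ccc(OCCO)nc4)c3c2)cc1NS(=O)(=O)c1ccc(F)cc1F` gives 2340 nM, and compound 2 `COc1ncc(-c2ccc3ncnc(Nc4cnn(CCCO)c4)c3c2)cc1NS(=O)(=O)c1ccc(F)cc1F` gives 480 nM, the lowest of the three in this assay. The cores of compound 3 and compound 2 differ by 1-(3-hydroxypropyl)-1H-pyrazol-4-yl in place of 6-(2-hydroxyethoxy)pyridin-3-yl on a nitrogen on an aromatic ring, and this gave a 4.9-fold higher number from compound 2 to compound 3 (0.69 log units; beyond the scatter). Compound 3 and compound 1 differ by methyl in place of 2,4-difluorophenyl on a sulfonyl sulfur, which gave a 2.3-fold higher number from compound 3 to compound 1 (0.36 log units; beyond the scatter). Compound 4 `COc1ncc(-c2ccc3ncnc(Nc4cnn(CCCO)c4)c3c2)cc1NS(C)(=O)=O` has not yet been measured; it differs from compound 2 by methyl in place of 2,4-difluorophenyl on a sulfonyl sulfur, the same change at the same place. Compound 4 is therefore expected to give about 1100 nM, with 550 nM to 2500 nM as the expected range. Going by the values given here, that expected step, a 2.3-fold higher number from compound 2 to compound 4 (0.36 log units; beyond the scatter), rests on a 2.3-fold higher number from compound 3 to compound 1 (0.36 log units; beyond the scatter) being the only earlier instance of this change.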

Compound 4, half-maximal inhibitory concentration: 1420 nM
Compound 4: middle estimate off by 1.3-fold (0.11 log units), on the low side; the range from low to high includes it.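

Putting methyl in place of 2,4-difluorophenyl on a sulfonyl sulfur raises the number in this assay on a second core (a 3.0-fold higher number from compound 2 to compound 4 (0.47 log units; beyond the scatter)), and the two instances of this change agree: the same change on two cores in this assay, a 2.3-fold higher number (0.36 log units; beyond the scatter) from compound 3 to compound 1 and a 3.0-fold higher number (0.47 log units; beyond the scatter) from compound 2 to compound 4, 1.3-fold (0.11 log units) apart, within the scatter of two such steps.
Putting 1-(3-hydroxypropyl)-1H-pyrazol-4-yl in place of 6-(2-hydroxyethoxy)pyridin-3-yl on a nitrogen on an aromatic ring lowers the number (a 3.8-fold lower number from compound 1 to compound 4 (0.58 log units; beyond the scatter)), and this change also carries over: the same change on two cores in this assay, a 4.9-fold higher number (0.69 log units; beyond the scatter) from compound 2 to compound 3 and a 3.8-fold higher number (0.58 log units; beyond the scatter) from compound 4 to compound 1, 1.3-fold (0.11 log units) apart, within the scatter of two such steps.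
Within these four compounds the two changes therefore behave independently of each other, but two cores in one cell assay do not show that the step would hold on any other core, nor why it occurs.

The compounds shown leave open what ethyl or unsubstituted phenyl on the sulfonyl sulfur would give. They also leave open whether an amine in place of the hydroxyl on the side chain would alter these steps.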